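This account rests on a few compounds, and the source may have more. Where it says the series, first, only, none or still open, it means among the compounds named here.

Compound 2, with the structure `CCC/C=C/COCC1C2CCC(O2)C1C/C=C\CCCC(=O)O`, gives 300 nM in a functional assay (plasma) for inhibition, with Homo sapiens as the target; a lower number here means a stronger inhibitor, a higher number a weaker inhibitor; that is the only number shown for it, and one further entry for it carries no single number. Compound 1, with the structure `CCCCCCOC[C@@H]1C2CCC(O2)[C@@H]1C/C=C\CCCC(=O)O`, is weaker in this assay and gives 38500 nM; 10000 nM (2 entries); its entries scatter, as the evidence shows: the several entries of compound 1 in this assay, 38500 nM; 10000 nM (2 entries). Compound 3, with the structure `COCC1C2CCC(O2)C1C/C=C\CCCC(=O)O`, has not yet been measured. It differs from compound 2 in one place: hydrogen in place of pent-1-en-1-yl on a saturated chain carbon bound to an oxygen on a saturated carbon. No measured pair among these compounds isolates a change of this kind, so the size of the step has to be guessed. Losing a chain of this length is expected to cost a great deal, well beyond the usual scatter, toward weaker inhibition. For compound 3 the expected result in this assay is 30000 nM, within a range of 4000 nM to 200000 nM. This estimate corresponds to the expected step of a 100-fold higher number from compound 2 to compound 3 (2.00 log units; beyond the scatter).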

Compound 3, half-maximal inhibitory concentration: 22000 nM
For compound 3 the middle estimate is 1.4-fold (0.13 log units) above the measured one, within the range that was stated.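

Cutting the ((hex-2-en-1-yl)oxy)methyl group back to methoxymethyl gives a 73-fold higher number from compound 2 to compound 3 (1.87 log units; beyond the scatter) in this assay, and this is the first pair here that differs in one place. It shows that the pent-1-en-1-yl part, on a saturated chain carbon bound to an oxygen, accounts for a large share of the inhibition seen with compound 2, while the methoxymethyl group alone leaves only weak inhibition. Nothing measured here says why this chain counts for so much.

As far as these compounds go, what happens between methyl and hex-2-en-1-yl remains open: a propyl chain would show whether inhibition builds up gradually with chain length. From the compounds shown here alone, it is also open whether a longer chain, such as octyl, or a phenyl ring at the end of the chain would go beyond compound 2.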